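Methoxy for Chloro on a Urea: Permeability Expectation

This account rests on a few compounds, and the source may have more. Where it says the series, first, only, none or still open, it means among the compounds named here.

Compound 1 `COc1cccc(NC(=O)Nc2cc(C)nc3ccccc23)c1` gives 818 10^-6 cm/s in an ADME assay for permeability, using PAMPA, at pH 7.4; a higher number here means that the compound crosses the layer faster, a lower number that the compound crosses the layer more slowly.
Compound 2 `Cc1cc(NC(=O)Nc2ccc(Cl)cc2)c2ccccc2n1` gives 537 10^-6 cm/s in this assay.
Compound 3 `Cc1cc(NC(=O)Nc2cccc(Cl)c2)c2ccccc2n1` gives 566 10^-6 cm/s in this assay.

Compound 2 and compound 3 have the same atoms joined differently: 4-chlorophenyl in place of 3-chlorophenyl on an amide-type nitrogen. The resulting step, a 1.1-fold higher number from compound 2 to compound 3 (0.02 log units; within the scatter), is small. Compound 1 differs from compound 3 by methoxy in place of chloro on an aromatic carbon, giving a 1.4-fold higher number from compound 3 to compound 1 (0.16 log units; within the scatter).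

Compound 4 `COc1ccc(NC(=O)Nc2cc(C)nc3ccccc23)cc1` has not yet been measured in this assay. It differs from compound 2 by methoxy in place of chloro on an aromatic carbon. This is the same kind of change as from compound 3 to compound 1, though the place differs: there the new group sat meta to a large group, here it sits para to a large group. The earlier step, a 1.4-fold higher number from compound 3 to compound 1 (0.16 log units; within the scatter), is the basis for the expectation. The expected step is a 1.3-fold higher number from compound 2 to compound 4 (0.13 log units; within the scatter). Compound 4 is therefore estimated at 720 10^-6 cm/s, probably between 450 10^-6 cm/s and 1100 10^-6 cm/s.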

Compound 4, apparent permeability: 787 10^-6 cm/s
Compound 4: the middle estimate sits 1.1-fold (0.04 log units) below what was measured; the range from low to high includes it.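

Putting methoxy in place of chloro at the new place gives a 1.5-fold higher number from compound 2 to compound 4 (0.17 log units; within the scatter). Set beside the earlier step, the change reads the same on both compounds in this assay: the same change on two cores in this assay, a 1.4-fold higher number (0.16 log units; within the scatter) from compound 3 to compound 1 and a 1.5-fold higher number (0.17 log units; within the scatter) from compound 2 to compound 4, 1.0-fold (0.01 log units) apart, within the scatter of two such steps

Each step lies within the scatter, so this agreement shows only that, in these two pairs, the swap stays within the usual spread of repeat measurements wherever it sits; it does not show that methoxy truly shifts the number, nor that the match would hold on more distant cores.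

The compounds shown leave open whether an amine, a carboxylic acid or a longer chain in this place would give a step beyond the scatter. They also leave open what a group other than methyl on the shared core would do.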